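A new aromatic group on the nitrogen of compound 1

The source may report more compounds than this note shows. Statements on the series, on what has been measured and on what is new or still open speak of the compounds shown alone.

Among the compounds with values here, in a functional assay on MCF7 cells (Homo sapiens) for antiproliferative activity, read by MTT assay, with a stated time of 72 h (on this read-out higher numbers stand for weaker inhibition and lower numbers for stronger inhibition), compound 1 (`C/C=C/C(=O)Nc1cccc(Oc2nc(Nc3ccn(C)n3)nc3c2CSCC3)c1`) gives 40000 nM and holds the only true number among the three compounds measured so far. Compound 2 (`CC/C=C/C(=O)Nc1cccc(Oc2nc(Nc3ccn(C)n3)nc3c2CSCC3)c1`) gives only a limit (> 50000 nM) in this assay. Compound 3 (`CC(C)=CC(=O)Nc1cccc(Oc2nc(Nc3ccn(C)n3)nc3c2CSCC3)c1`) likewise gives only a limit (> 50000 nM) in this assay.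

Compound 4 (`C/C=C/C(=O)Nc1cccc(Oc2nc(Nc3ccc(OC)cc3)nc3c2CSCC3)c1`) departs from compound 1 in one place: 4-methoxyphenyl in place of 1-methyl-1H-pyrazol-3-yl on a nitrogen on an aromatic ring while the rest of the structure stays the same.

Two measured steps start from compound 1. One is an at least 1.2-fold higher number from compound 1 to compound 2 (0.09 log units; that floor lies within the scatter) and the other is an at least 1.2-fold higher number from compound 1 to compound 3 (0.09 log units; that floor lies within the scatter) and both stay within the scatter. Both alter the group on the carbonyl carbon, and neither touches the 1-methyl-1H-pyrazol-3-yl group that now leaves. Within the data shown here, no measured step therefore speaks directly to this exchange.

The expectation rests on compound 1 and its value (40000 nM), so no shift beyond the scatter is expected in this assay. A reading for compound 4 that is only a limit would be no surprise. The expected change is a 1.3-fold lower number from compound 1 to compound 4 (0.12 log units; within the scatter) with little confidence in its direction. For compound 4 the estimated value is 30000 nM with an expected range from 8000 nM to 50000 nM in this assay when it is measured.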

Compound 4, half-maximal inhibitory concentration: 24300 nM
For compound 4 the middle estimate is 1.2-fold (0.09 log units) above the measured one; the range from low to high includes it.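

The exchange on the nitrogen gives a 1.6-fold lower number from compound 1 to compound 4 (0.22 log units; within the scatter) in this assay, and this is the only step shown that joins two true numbers and the only one that touches this nitrogen rather than the group on the carbonyl carbon. It shows that, for this one pair, 1-methyl-1H-pyrazol-3-yl, a five-membered aromatic ring with 2 hetero atoms, can give way to 4-methoxyphenyl, a six-membered aromatic ring of carbon only, without a shift beyond the scatter. Compound 4 also keeps a true number on the unchanged prop-1-en-1-yl amide, in a small set where limits remain common: the limit of > 50000 nM in this assay, at which 2 of the 4 values shown sit.

Because the ring and the methoxy group change together in this one exchange, the compounds shown do not separate their contributions, and a plain phenyl group or a phenyl carrying an amine such as piperazine would be needed to tell whether anything on this nitrogen moves the number beyond the scatter. As far as these compounds go, it also stays open whether the butenyl or methylpropenyl amides would behave the same way alongside 4-methoxyphenyl, and the step between compound 2 and compound 3 cannot be read.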